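The source may report more compounds than this note shows. Statements on the series, on what has been measured and on what is new or still open speak of the compounds shown alone.

Compound 1 `CN1CCN(c2nc(-c3cccc(Cl)c3)nc3[nH]cnc23)CC1` is examined in an assay on cells for displacement of a labelled ligand from adenosine receptor A1 (Homo sapiens), read by scintillation counting and radioligand binding, with a stated time of 60 min (a higher number here means a weaker inhibitor, a lower number a stronger inhibitor), where compound 1 gives 79.4 nM. Among the three compounds measured, compound 1 holds the second highest number. For the measured compounds named here, its nearest neighbour is compound 3 `Clc1cccc(-c2nc(N3CCCCC3)c3nc[nH]c3n2)c1`, which gives 50.1 nM; the only single-site step among the measured compounds, a 1.6-fold lower number from compound 1 to compound 3 (0.20 log units; within the scatter), replaces 4-methylpiperazin-1-yl with piperidin-1-yl on an aromatic carbon. Going by the values given here, compound 2 `CN1CCN(c2nc(-c3ccccc3O)nc3c2ncn3C)CC1` gives 631 nM, the highest number of the set, but compound 2 differs from compound 1 in two places, so no single step connects the pair.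

The move to compound 4 `CN1CCN(c2nc(-c3ccc(O)cc3)nc3[nH]cnc23)CC1` alters the other side of the shared core: 4-hydroxyphenyl in place of 3-chlorophenyl on an aromatic carbon. Among the compounds with values here, none of the measured steps touches this aryl group directly; the single measured step concerns the 4-methylpiperazin-1-yl side and lay within the scatter, so it offers little guidance here. Within the data shown here, the only pointer is that compound 2, which keeps the 4-methylpiperazin-1-yl group and changes the aryl group together with a second alteration, shows the weaker number. Compound 4 is therefore expected to give a moderately higher number in this assay, a 3.1-fold higher number from compound 1 to compound 4 (0.50 log units; beyond the scatter). The estimate for compound 4 is 250 nM, with a range from 80 nM to 800 nM.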

Compound 4, inhibition constant: 398 nM
Compound 4: middle estimate off by 1.6-fold (0.20 log units), on the low side; the measured number falls inside the stated range.
By their numbers in this assay, from the lowest: compounds 3 and 1 (each within the scatter of the next); then compounds 4 and 2 (each within the scatter of the next).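

For the compounds shown here, with the 4-methylpiperazin-1-yl group held fixed, replacing 3-chlorophenyl with 4-hydroxyphenyl on the aromatic carbon between two ring nitrogen atoms gives in this assay a 5.0-fold higher number from compound 1 to compound 4 (0.70 log units; beyond the scatter) and is the first single-site change in the set to lie beyond the scatter, whereas the earlier step at the 4-methylpiperazin-1-yl site, a 1.6-fold lower number from compound 1 to compound 3 (0.20 log units; within the scatter) and within the scatter, showed no such separation. The aryl position is therefore the first site at which a single change is seen to move the number by more than the scatter, and here that movement is towards a weaker inhibitor. The swap exchanges chlorine for hydroxy and also moves the substituent from the 3 to the 4 position of the phenyl ring. The step cannot apportion its size between the two. No supporting data are available to account for it.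

Going by these compounds, how a 3-hydroxyphenyl or a 4-chlorophenyl group would stand in this position remains open, and these are the groups that would separate the substituent from its place on the ring. Also open, on these data alone, is whether the same aryl swap would give a step of similar size with piperidin-1-yl in place of 4-methylpiperazin-1-yl.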